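Swapping the distal ring of a biphenyl propanamide

A few compounds are considered here, and "the series" means these few. Any claim that something is new, unique, unknown or untested is made for them only; others in the source may bear on it.

Among the measured compounds shown here, compound 2 `O=C(CCc1ccc(-c2ccc(Cl)cc2)cc1)N1CCCC1` gives 48600 nM in an assay on HEK293 cells for inhibition of N-acylethanolamine-hydrolyzing acid amidase (Rattus norvegicus), read by LC-MS, with a stated time of 30 min (on this read-out higher numbers stand for weaker inhibition and lower numbers for stronger inhibition), the highest of the two numbers measured so far. Its nearest neighbour is compound 1 `Cc1cccc(-c2ccc(CCC(=O)N3CCCC3)cc2)c1`, which in this assay gives 16500 nM; the step of a 2.9-fold higher number from compound 1 to compound 2 (0.47 log units; beyond the scatter) shows that exchanging the distal aromatic ring moves the read-out modestly but beyond the scatter. Compound 3 `O=C(CCc1ccc(-c2ccccn2)cc1)N1CCCC1` differs from compound 2 by pyridin-2-yl in place of 4-chlorophenyl on an aromatic carbon. For the measured compounds named here, only the single step from compound 1 to compound 2 bears on this change, since it too alters the ring at the same position, and it was of modest size. A step of similar magnitude in this assay is therefore expected for compound 3, with no firm basis for its direction. Compound 3 is estimated at 30000 nM in this assay, within a range of 8000 nM to 120000 nM, which corresponds to an expected step of a 1.6-fold lower number from compound 2 to compound 3 (0.21 log units; within the scatter).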

Compound 3, half-maximal inhibitory concentration: > 100000 nM
Compound 3: a limit, no number; the forecaster's own chance of this, stated with the estimate: 15%; at least 3.3-fold (0.52 log units) between middle value and limit.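

Compound 3 stands at a limit, not at a number, in this assay: the limit of > 100000 nM in this assay, at which 1 of the 3 values shown sits. Pyridin-2-yl in place of 4-chlorophenyl gives an at least 2.0-fold higher number from compound 2 to compound 3 (0.31 log units; beyond the scatter), and pyridin-2-yl in place of 3-methylphenyl gives an at least 6.0-fold higher number from compound 1 to compound 3 (0.78 log units; beyond the scatter). Among the compounds shown here, the earlier pair compared only two rings of carbon, whereas this change brings in a ring with a hetero atom and gives the weakest inhibition of the three compounds, so the read-out at this position moves further than the earlier step showed.

The change removes the chlorine and adds the ring nitrogen together, so the compounds shown do not separate the two, and a plain phenyl ring would be needed for that. On these data alone, whether pyridin-3-yl or pyridin-4-yl at this position behaves like pyridin-2-yl also remains open.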